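Moving a Bromine on Three Weakly Inhibiting Compounds

This account rests on a few compounds, and the source may have more. Where it says the series, first, only, none or still open, it means among the compounds named here.

Compound 1 `Fc1ccc(/C=N/Nc2nc(-c3cc(C(F)(F)F)cc(C(F)(F)F)c3)cs2)cc1F`: > 100000 nM
Compound 2 `COc1cc(/C=N/Nc2nc(-c3ccc(Br)cc3)cs2)cc(Br)c1OC`: > 100000 nM
Compound 3 `COc1cc(/C=N/Nc2nc(-c3ccc(C(F)(F)F)cc3)cs2)c(Br)c(Br)c1OC`: > 100000 nM

In an ADME assay on HUVEC cells (Homo sapiens) for inhibition, read by MTT assay, with a stated time of 48 h (a lower number here means a stronger inhibitor, a higher number a weaker inhibitor), compound 1 gives only a limit of the assay, > 100000 nM. Compound 2 likewise gives only a limit, > 100000 nM. Compound 3 also reaches only a limit, > 100000 nM. So compound 2 stands with the others at the limit of > 100000 nM in this assay, at which 3 of the 3 values shown sit, and no measured number separates any of the three.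

Compound 4 `COc1cc(/C=N/Nc2nc(-c3cccc(Br)c3)cs2)cc(Br)c1OC` differs from compound 2 in one place: 3-bromophenyl in place of 4-bromophenyl on an aromatic carbon. Among the compounds with values here, no measured pair shows the effect of such a change. Since compound 2 sits at a limit, the expected step that the limit leaves unreadable from compound 2 to compound 4 is none beyond the scatter, with compound 4 most likely reported as a limit again. Compound 4 is therefore estimated at 150000 nM, ranging from 40000 nM to 600000 nM.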

Compound 4, half-maximal inhibitory concentration: > 100000 nM
Compound 4 was reported as a limit; the forecaster's own chance of this, stated with the estimate: 85%; the middle value lies beyond the limit too.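

Compound 2 and compound 4 both end at a limit of the assay, so no step between them can be read: the limit of > 100000 nM in this assay, at which 4 of the 4 values shown sit.

Going by these compounds, whether 3-bromophenyl and 4-bromophenyl differ at all in this assay stays open.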